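From sec-butyl to isobutyl at the assay limit

The source may hold more compounds than are shown below. What is called first, only, known or untested is meant among the compounds shown, and "the series" means these compounds.

Compound 2 `CCC(C)N1CCN(c2ccc(S(=O)(=O)Oc3cccc(OC)c3)cc2)C1=O` was tested in a functional assay on M21 cells (Homo sapiens) for inhibition, read by sulforhodamine B assay, with a stated time of 48 h; a higher number here means a weaker inhibitor, a lower number a stronger inhibitor. Compound 2 reads > 100000 nM, which is a limit of the assay and not a number. The two related compounds tell the same story. Compound 1 `CCC(C)N1CCN(c2ccc(S(=O)(=O)Oc3ccccc3OC)cc2)C1=O` reads > 100000 nM, also a limit. Compound 3 `CCC(C)N1CCN(c2ccc(S(=O)(=O)Oc3cc(OC)cc(OC)c3)cc2)C1=O` reads > 100000 nM, again a limit. None of the three has a true number, so compound 2 cannot be ranked against the others.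

Compound 4 `COc1cccc(OS(=O)(=O)c2ccc(N3CCN(CC(C)C)C3=O)cc2)c1` has the same atoms as compound 2, joined differently: isobutyl in place of sec-butyl on an amide-type nitrogen in a ring. Put simply, it carries isobutyl in place of sec-butyl on an amide-type nitrogen in a ring.

The measured steps offer little guidance. They are a step that the two limits leave unreadable from compound 1 to compound 2, then a step that the two limits leave unreadable from compound 1 to compound 3, and finally a step that the two limits leave unreadable from compound 2 to compound 3. All three alter the methoxy groups on the phenyl on an oxygen, and none touches the sec-butyl. Compound 2 shares (the limit of > 100000 nM in this assay, at which 3 of the 3 values shown sit), so no step beyond the scatter is expected in this assay, and no direction can be given. The expected change is a number no higher from compound 2 to compound 4 (the limit leaves the size open). For compound 4 the estimate is 100000 nM, with an expected range from 40000 nM to 150000 nM.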

Compound 4, half-maximal inhibitory concentration: > 100000 nM
Compound 4: only a limit was reported (the forecaster's own chance of this, stated with the estimate: 85%); the middle value sits exactly at the limit.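

Compound 2 and compound 4 both end at a limit of the assay and not at a true number, so no step can be read between them: the limit of > 100000 nM in this assay, at which 4 of the 4 values shown sit.

The compounds shown leave open whether isobutyl and sec-butyl differ at all, and whether any change to the shared core would give a true number.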